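Prenyl Addition in a Polyprenylated Acylphloroglucinol Series

The source may hold more compounds than are shown below. What is called first, only, known or untested is meant among the compounds shown, and "the series" means these compounds.

Measured compounds in a functional assay on HCT-116 cells (Homo sapiens) for inhibition; a higher number here means a weaker inhibitor, a lower number a stronger inhibitor:
- compound 1 `CC(C)=CCC/C(C)=C/C[C@]12C[C@@H](CC=C(C)C)C(C)(C)[C@](CC=C(C)C)(C(=O)CC1=O)C2=O`: 6.46 ug/mL
- compound 2 `CC(C)=CCC/C(C)=C/C[C@@H]1C[C@]2(CC=C(C)C)C(=O)[C@@](CC=C(C)C)(C(=O)C(C(=O)c3ccc(O)c(O)c3)=C2O)C1(C)C`: value given only as a limit, > 20 ug/mL
- compound 3 `CC(C)=CCC/C(C)=C/C[C@@H]1C[C@@]2(C/C=C(\C)CCC=C(C)C)C(=O)CC(=O)[C@](CC=C(C)C)(C2=O)C1(C)C`: value given only as a limit, > 20 ug/mL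

Two of the three values sit at the limit of > 20 ug/mL in this assay, at which 2 of the 3 values shown sit, so compound 1 alone gives a number. The change from compound 1 to compound 3 is 3-methylbut-2-en-1-yl in place of hydrogen on a saturated chain carbon bound to a double-bonded chain carbon, and it made a step of an at least 3.0-fold higher number from compound 1 to compound 3 (0.49 log units; beyond the scatter). Compound 2 and compound 1 differ across more of the molecule; the difference between the two cores is not broken down here.

Compound 4 `CC(C)=CCC/C(C)=C/C[C@@H]1C[C@]2(C/C=C(\C)CCC=C(C)C)C(=O)[C@@](CC=C(C)C)(C(=O)C(C(=O)c3ccc(O)c(O)c3)=C2O)C1(C)C` is not yet measured. Its change from compound 2 is 3-methylbut-2-en-1-yl in place of hydrogen on a saturated chain carbon bound to a double-bonded chain carbon, the same kind of change as the one seen before, at the same kind of place. The step is expected to be a step that the limit leaves unreadable from compound 2 to compound 4, beside an at least 3.0-fold higher number from compound 1 to compound 3 (0.49 log units; beyond the scatter), resting on compound 2 already standing at a limit and on the earlier step weakening inhibition. Compound 4 is therefore estimated at 40 ug/mL, spanning 15 ug/mL to 150 ug/mL, most likely reported only as a limit.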

Compound 4, half-maximal inhibitory concentration: 4.92 ug/mL
Beside the measured number, compound 4's estimate is 8.1-fold (0.91 log units) above it; the whole stated range lies above it.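

In this assay, adding 3-methylbut-2-en-1-yl on a saturated chain carbon bound to a double-bonded chain carbon gives an at least 4.0-fold lower number from compound 2 to compound 4 (0.60 log units; beyond the scatter). The same change therefore does not carry over in direction from one core to the other: the same change on two cores in this assay, an at least 3.0-fold higher number (0.49 log units; beyond the scatter) from compound 1 to compound 3 and an at least 4.0-fold lower number (0.60 log units; beyond the scatter) from compound 2 to compound 4, at least 12-fold (1.09 log units) apart, beyond the scatter of two such steps Each step has one end at a limit, so neither size is known exactly, and nothing here shows which part of the two cores reverses the outcome.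

Left open is whether a saturated pentyl chain, or a chain ending in an amine or a carboxylic acid, at the same place would follow either core. With only two cores shown, no rule can be drawn for a further core.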